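This account rests on a few compounds, and the source may have more. Where it says the series, first, only, none or still open, it means among the compounds named here.

Measured so far:
compound 1, `CC(C)c1ccc(Nc2ccc3c(OCCCN4CCN(C)CC4)cccc3n2)cc1`, 13400 nM
compound 2, `CN1CCN(CCCOc2cccc3nc(Nc4ccc(F)c(F)c4)ccc23)CC1`, 4070 nM

Both were tested in a functional assay on cells (Panel prostate (Carcinoma cell lines), Homo sapiens) for inhibition, read by sulforhodamine B assay, with a stated time of 48 h; a higher number here means a weaker inhibitor of growth, a lower number a stronger inhibitor of growth. Compound 2 has the lowest of the two numbers; its nearest neighbour, compound 1, sits higher by a 3.3-fold lower number from compound 1 to compound 2 (0.52 log units; beyond the scatter). Compound 3, `CN1CCN(CCCOc2cccc3nc(Nc4cc(Cl)cc(Cl)c4)ccc23)CC1`, has not been measured yet. It differs from compound 2 by 3,5-dichlorophenyl in place of 3,4-difluorophenyl on a nitrogen on an aromatic ring. Among the measured compounds shown here, the only step that bears on this is the one at the same place, which was modest, so a change near the scatter in either direction is expected, leaning toward a similar number. For compound 3 the estimate is 3500 nM (range 1200 nM to 10000 nM), meaning an expected step of a 1.2-fold lower number from compound 2 to compound 3 (0.07 log units; within the scatter).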

Compound 3, concentration for 50% growth inhibition: 1730 nM
The estimate for compound 3 lay 2.0-fold (0.31 log units) above the measured number; measured number inside the range.
By their numbers in this assay, from the lowest: compound 3; then compound 2; then compound 1.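

Within this assay, the aryl group on the nitrogen responds to a second change, with a 2.4-fold lower number from compound 2 to compound 3 (0.37 log units; beyond the scatter) and with a 7.7-fold lower number from compound 1 to compound 3 (0.89 log units; beyond the scatter) as the widest step so far. Going from 3,4-difluorophenyl to 3,5-dichlorophenyl changes both the halogen and its placement, so this step cannot be credited to either one alone. Nothing measured here explains the step.

The compounds shown leave open how 3,4-dichlorophenyl and 3,5-difluorophenyl would compare, which could separate the two changes. Plain phenyl also remains open as a reference for the aryl groups.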